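This account rests on a few compounds, and the source may have more. Where it says the series, first, only, none or still open, it means among the compounds named here.

Measured so far:
compound 1, `CC(=O)N1N=C(c2cccc3ccccc23)CC1c1ccccc1`: 11200 nM
compound 2, `CC(=O)N1N=C(c2cccc3ccccc23)CC1c1ccccc1[N+](=O)[O-]`: 3960 nM
compound 3, `O=CCN1N=C(c2ccc3ccccc3c2)CC1c1ccccc1`: 8400 nM

In a functional assay on HEp-2 cells (Homo sapiens) for cytotoxicity, read by sulforhodamine B assay, with a stated time of 48 h (a higher number here means a weaker inhibitor, a lower number a stronger inhibitor), compound 1 gives 11200 nM. Compound 2 differs from compound 1 by nitro in place of hydrogen on an aromatic carbon, and this change gives a 2.8-fold lower number from compound 1 to compound 2 (0.45 log units; beyond the scatter). In this assay compound 3 gives 8400 nM; compound 3 and compound 1 have the same atoms joined differently, and the difference between the two cores is not broken down here. Compound 4, `O=CCN1N=C(c2ccc3ccccc3c2)CC1c1cccc([N+](=O)[O-])c1`, has not yet been measured. It differs from compound 3 by nitro in place of hydrogen on an aromatic carbon. This is the same kind of change as that from compound 1 to compound 2, but the place is not the same: in compound 2 the nitro stands ortho to a large group, whereas in compound 4 it stands meta to a large group. Among the compounds with values here, only one such step has been measured, on a core whose relation to the core of compound 3 is not broken down here, so the expectation rests on a 2.8-fold lower number from compound 1 to compound 2 (0.45 log units; beyond the scatter) alone. Given the different place and core, compound 4 is expected to show a somewhat smaller step, a 2.1-fold lower number from compound 3 to compound 4 (0.32 log units; beyond the scatter). Compound 4 is thus expected to give about 4000 nM in this assay, estimated to lie between 1600 nM and 9500 nM.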

Compound 4, half-maximal inhibitory concentration: 3870 nM
Estimate against measurement, compound 4: 1.0-fold (0.01 log units) above, and the stated range covers the measured number.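

In this assay, nitro in place of hydrogen on an aromatic carbon gives a 2.2-fold lower number from compound 3 to compound 4 (0.34 log units; beyond the scatter), so the lowering seen on the core of compound 1 also appears on a second core. Set side by side, the two steps do not differ: the same change on two cores in this assay, a 2.8-fold lower number (0.45 log units; beyond the scatter) from compound 1 to compound 2 and a 2.2-fold lower number (0.34 log units; beyond the scatter) from compound 3 to compound 4, 1.3-fold (0.11 log units) apart, within the scatter of two such steps. This shows that the change carried over between these two cores in this one assay, but it does not separate the effect of core from that of place, since the nitro does not stand in the same place in compound 2 and compound 4, and two pairs of compounds establish no rule for the whole series.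

The compounds shown leave open whether nitro would give the same step if its place were exchanged between the two cores. They also leave open whether another group in that place, such as an amine or a carboxylic acid, would lower the number as nitro does.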